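Pyrrolidine at the Chain End of the Thioether Compound

This account rests on a few compounds, and the source may have more. Where it says the series, first, only, none or still open, it means among the compounds named here.

Among the three measured compounds, compound 3 `CCCCCSc1nc(C(C)(C)C)ccc1CNC(=O)C(C)c1ccc(NS(C)(=O)=O)c(F)c1` gives the highest number in an assay on cells for antagonist activity at transient receptor potential cation channel subfamily V member 1 (Homo sapiens), read by FLIPR and calcium flux, with a stated time of 6 min (a higher number here means a weaker inhibitor, a lower number a stronger inhibitor), at 3.1 nM. Its nearest neighbour is compound 1 `CCCN(CCC)c1nc(C(C)(C)C)ccc1CNC(=O)C(C)c1ccc(NS(C)(=O)=O)c(F)c1`, which in this assay gives 2.5 nM; the gap between them, a 1.2-fold higher number from compound 1 to compound 3 (0.09 log units; within the scatter), is within the scatter. Compound 2 `CCC1CCN(c2nc(C(C)(C)C)ccc2CNC(=O)C(C)c2ccc(NS(C)(=O)=O)c(F)c2)CC1` is furthest away, at 0.1 nM in this assay, and the step of a 31-fold higher number from compound 2 to compound 3 (1.49 log units; beyond the scatter) is large, as is a 25-fold lower number from compound 1 to compound 2 (1.40 log units; beyond the scatter).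

Compound 4 `CC(C(=O)NCc1ccc(C(C)(C)C)nc1SCCCN1CCCC1)c1ccc(NS(C)(=O)=O)c(F)c1` is reached from compound 3 by pyrrolidin-1-yl in place of ethyl on a saturated chain carbon, three bonds along the chain from a sulfur. Going by the values given here, none of the measured steps touches this part of the molecule: all three concern the group on the aromatic carbon, and no pair of measured compounds differs only at the end of the chain. The large steps involving compound 2 therefore do not bear on it, and the within-scatter step from compound 1 to compound 3 only shows that chain and amine attachments can give similar numbers. Among the compounds with values here, with no precedent, the expected step of a 1.0-fold lower number from compound 3 to compound 4 (0.01 log units; within the scatter) is none beyond the scatter. Compound 4 is therefore estimated at 3 nM in this assay, with a range from 0.8 nM to 12 nM.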

Compound 4, inhibition constant: 17.1 nM
Estimate against measurement, compound 4: 5.7-fold (0.76 log units) below, and the stated range ends below it.
By their numbers in this assay, from the lowest: compound 2; then compounds 1 and 3 (each within the scatter of the next); then compound 4.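

The chain end is not a silent position in this assay: pyrrolidin-1-yl in place of ethyl, on a saturated chain carbon three bonds along the chain from a sulfur, gives a 5.5-fold higher number from compound 3 to compound 4 (0.74 log units; beyond the scatter) and so moves the compound towards weaker inhibition. The thioether with this ending also separates from the amine-linked compounds, with a 6.8-fold higher number from compound 1 to compound 4 (0.84 log units; beyond the scatter) and a 170-fold higher number from compound 2 to compound 4 (2.23 log units; beyond the scatter), whereas pentylsulfanyl and dipropylamino had stayed within the scatter of each other. Nothing in the data given accounts for this change.

Going by these compounds, it remains open whether the change belongs to the pyrrolidine ring or to any amine at this chain end. A dimethylamino group, a morpholine or a carboxylic acid at the same place, or a shorter or longer chain carrying the pyrrolidine, would bear on that question.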